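A few compounds are considered here, and "the series" means these few. Any claim that something is new, unique, unknown or untested is made for them only; others in the source may bear on it.

Working notes on the carbamate series.

Compound 1 `N#Cc1ccnc(OC(=O)N2CCC(C(c3ccccc3)c3ccccc3)CC2)c1` carries the diphenylmethyl substituent on the shared core. In an assay on isolated protein for inhibition of Fatty-acid amide hydrolase 1 (Rattus norvegicus), read by fluorescence (on this read-out higher numbers stand for weaker inhibition and lower numbers for stronger inhibition), compound 1 gives only a limit, > 1000 nM, so its true value is not known. Compound 2 `N#Cc1cccc(OC(=O)N2CCC(S(=O)(=O)C(c3ccccc3)c3ccccc3)CC2)c1` has no result in this assay; for compound 2 the entry reads "not determined" (no result reported). Among the measured compounds shown here, compound 3 `N#Cc1cccc(OC(=O)N2CCC(Cc3ccccc3)CC2)c1`, with a benzyl group in place of the larger substituent, is the only member with a number: in this assay compound 3 gives 44.7 nM. Compound 1 therefore stands at the weak end of what is shown, at the limit noted as the limit of > 1000 nM in this assay, at which 1 of the 3 values shown sits.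

Compound 4 `COc1cc(C#N)cc(OC(=O)N2CCC(C(c3ccccc3)c3ccccc3)CC2)c1` is not yet measured. It differs from compound 1 by 3-cyano-5-methoxyphenyl in place of 4-cyanopyridin-2-yl on an oxygen next to a carbonyl group. For the measured compounds named here, no measured pair isolates this change. Going by the values given here, the aryl carbamate of compound 3 is the one active example, so a gain is expected for compound 4, a step of an at least 2.5-fold lower number from compound 1 to compound 4 (0.39 log units; beyond the scatter) from the limit into the measurable range. Compound 4 is estimated at 400 nM, within 60 nM to 3000 nM.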

Compound 4, half-maximal inhibitory concentration: > 1000 nM
Compound 4 was reported as a limit; the forecaster's own chance of this, stated with the estimate: 35%; middle value at least 2.5-fold (0.39 log units) from the limit.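

Among the compounds shown here, compound 1 and compound 4 both stand only as limits in this assay, so no step between them can be read: the limit of > 1000 nM in this assay, at which 2 of the 4 values shown sit. The compounds shown leave open whether 3-cyano-5-methoxyphenyl in place of 4-cyanopyridin-2-yl changes inhibition on the diphenylmethyl-bearing core at all.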